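Swapping the sulfonyl substituent of compound 2

The source may hold more compounds than are shown below. What is called first, only, known or untested is meant among the compounds shown, and "the series" means these compounds.

Compound 1 `O=C(NCc1ccc(S(=O)(=O)c2ccccc2)cc1)NCc1cccnc1` gives 610 nM
Compound 2 `CCCn1cc(S(=O)(=O)c2ccc(CNC(=O)N3Cc4ccncc4C3)cc2)cn1` gives 7.3 nM

Both numbers come from a functional assay on A2780 cells (Homo sapiens) for cytotoxicity, read by sulforhodamine B assay, with a stated time of 72 h (on this read-out lower numbers stand for stronger inhibition and higher numbers for weaker inhibition), and compound 2 stands lowest of the two, at 7.3 nM (clearly beyond the usual scatter from compound 1). Compound 3 `O=C(NCc1ccc(S(=O)(=O)C2CCCOC2)cc1)N1Cc2ccncc2C1` has not yet been measured. It has oxan-3-yl in place of 1-propyl-1H-pyrazol-4-yl on a sulfonyl sulfur. Going by the values given here, no measured pair here shows this kind of change, so the expectation is only a judgement: a moderately higher number in this assay that is probably beyond the scatter. The expected size is a 3.4-fold higher number from compound 2 to compound 3 (0.53 log units; beyond the scatter) (an estimate). For compound 3 the estimated value is 25 nM (expected range 6 nM to 100 nM).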

Compound 3, half-maximal inhibitory concentration: 32 nM
The estimate for compound 3 lay 1.3-fold (0.11 log units) below the measured number; low and high end bracket the measured number.
By their numbers in this assay, from the lowest: compound 2; then compound 3; then compound 1.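

In this assay, going by these compounds alone, oxan-3-yl in place of 1-propyl-1H-pyrazol-4-yl on a sulfonyl sulfur gives a 4.4-fold higher number from compound 2 to compound 3 (0.64 log units; beyond the scatter) and this is the first view of this position alone, as compound 1 and compound 2 differ in more than one place. A change here by itself moves the number beyond the scatter, yet a non-aromatic ring still leaves compound 3 well below compound 1. Nothing available explains the size of this step.
From the compounds shown here alone, how a cyclohexyl ring, which is oxan-3-yl with carbon in place of its oxygen, would compare remains open. So does the effect of an open propyl chain on the sulfonyl sulfur.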